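The compounds below may be only part of what the source reports. "The series", "measured", "known", "first", "only" and "open" are said of these compounds alone.

Series notes. The shared core is that of compound 1 `CC1=NN(c2ccccc2)C(=O)C12C=CC(=O)C=C2c1cccc(C)c1`. In a functional assay on HCT-116 cells (Homo sapiens) for antiproliferative activity, read by CCK-8 assay, with a stated time of 72 h (a lower number here means a stronger inhibitor, a higher number a weaker inhibitor), compound 1 returns only a limit, > 100000 nM, not a number (the limit of > 100000 nM in this assay, at which 1 of the 3 values shown sits). For the measured compounds named here, the one single-point step recorded in the set is an at least 11-fold lower number from compound 1 to compound 3 (1.07 log units; beyond the scatter), a methyl in place of hydrogen on an aromatic carbon, and it was large. Compound 3 `CC1=NN(c2ccc(C)cc2)C(=O)C12C=CC(=O)C=C2c1cccc(C)c1` gives 8340 nM in this assay. Compound 2 `CC1=NN(c2cccc(Cl)c2)C(=O)C12C=CC(=O)C=C2c1ccc(C)cc1` carries a 3-chlorophenyl on the amide-type nitrogen in a ring and a 4-methylphenyl elsewhere; in this assay compound 2 gives 2400 nM. Of the two numerical values, compound 3 stands as the higher one, with compound 2 the only other point, its number lower by a gap beyond the scatter.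

The next step, compound 4 `CC1=NN(c2cccc(Cl)c2)C(=O)C12C=CC(=O)C=C2c1cccc(C)c1`, is 3-chlorophenyl in place of 4-methylphenyl on an amide-type nitrogen in a ring. Going by the values given here, no measured step bears directly on this exchange on the ring nitrogen; the one step that exists concerns the methyl on an aromatic carbon. Among the compounds with values here, compound 2 shows that a 3-chlorophenyl on the amide-type nitrogen is compatible with a number below that of compound 3, but its other ring also differs, so no step can be drawn from the pair. The expectation for compound 4 is therefore a modest move to a lower number, a 2.1-fold lower number from compound 3 to compound 4 (0.32 log units; beyond the scatter), close to the scatter. The estimate for compound 4 in this assay is 4000 nM, with a range from 1200 nM to 15000 nM.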

Compound 4, half-maximal inhibitory concentration: 3740 nM
Beside the measured number, compound 4's estimate is 1.1-fold (0.03 log units) above it; the measured number falls inside the stated range.
By their numbers in this assay, from the lowest: compounds 2 and 4 (each within the scatter of the next); then compound 3. At a limit, above all of these: compound 1.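

For the compounds shown here, on the amide-type nitrogen in a ring, 3-chlorophenyl in place of 4-methylphenyl gives the first direct reading at this position in this assay, a 2.2-fold lower number from compound 3 to compound 4 (0.35 log units; beyond the scatter), a modest step; on the double-bonded ring carbon, 3-methylphenyl in place of 4-methylphenyl gives a 1.6-fold higher number from compound 2 to compound 4 (0.19 log units; within the scatter), so the position of the methyl on that ring makes no readable difference in this pair. With the 3-methylphenyl held constant, adding a chloro to the phenyl on the ring nitrogen gives an at least 26-fold lower number from compound 1 to compound 4 (1.42 log units; beyond the scatter), a large step and the second, after the methyl step, to lead away from the unsubstituted phenyl. Compound 1 gives a limit and not a number, so both of these large steps have an open end: the limit of > 100000 nM in this assay, at which 1 of the 4 values shown sits.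

The compounds shown leave open whether the chloro and methyl groups are interchangeable on the phenyl on the ring nitrogen, since a 4-chlorophenyl and a 3-methylphenyl do not appear there in this set. They also leave open how the series responds to an amine or a carboxylic acid on either phenyl, or to a longer chain in place of the methyl on the ring atom that bears it.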